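Swapping a dimethoxypyrimidine for a dichlorophenyl: expected cytotoxicity

This account rests on a few compounds, and the source may have more. Where it says the series, first, only, none or still open, it means among the compounds named here.

Of the compounds shown here, three have so far been tested in an ADME assay on HEK293 cells (Homo sapiens) for cytotoxicity, read by CellTiter-Glo and resazurin assay, with a stated time of 72 h; a higher number here means that more compound is needed for the effect, a lower number that less compound is needed. Compound 1 `CC(C)N(Cc1cccc(OCCCCCC(=O)O)c1)C(=O)c1ccc(-c2cccc(Oc3ccccc3)c2)cc1` gives a limit rather than a number, > 18700 nM. Compound 2 `COc1cc(F)cc(-c2ccc(C(=O)N(Cc3cccc(OCCCCCC(=O)O)c3)C(C)C)cc2)c1` also reaches only a limit, > 26000 nM. Compound 3 `CCOC(=O)CCCCCOc1cccc(CN(C(=O)c2ccc(-c3cnc(OC)nc3OC)cc2)C(C)C)c1` likewise stops at a limit, > 26000 nM. Compound 3 therefore stands at the same limit as compound 2, the one shared by two of the three values, (the limit of > 26000 nM in this assay, at which 2 of the 3 values shown sit), while the remaining value sits at a lower limit, (the limit of > 18700 nM in this assay, at which 1 of the 3 values shown sits). None of the three compounds produced a measurable loss of cell viability within the concentrations tested.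

Compound 4 `CCOC(=O)CCCCCOc1cccc(CN(C(=O)c2ccc(-c3ccc(Cl)c(Cl)c3)cc2)C(C)C)c1` differs from compound 3 in one place: 3,4-dichlorophenyl in place of 2,4-dimethoxypyrimidin-5-yl on an aromatic carbon. Going by the values given here, no pair of measured compounds that differ in a single place is available, so the size of this step cannot be read from the data. All three values sit at limits, which leaves no measured trend to build on. For compound 4 the expected step is an at least 1.0-fold lower number from compound 3 to compound 4 (0.01 log units; that floor lies within the scatter), that is no movement beyond the usual scatter, with some chance of a modest drop. Compound 4 is thus expected to give about 25000 nM, within a range from 8000 nM to 50000 nM, and quite possibly again only a limit.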

Compound 4, half-maximal effective concentration: > 26000 nM
Compound 4 gave a limit, no number; the forecaster's own chance of this, stated with the estimate: 60%; at least 1.0-fold (0.01 log units) between middle value and limit.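

Compound 3 and compound 4 both end at a limit in this assay rather than at a number, so the step between them cannot be read. The compounds shown leave open at what concentration either one would affect the cells, and whether 3,4-dichlorophenyl in place of 2,4-dimethoxypyrimidin-5-yl shifts that concentration at all.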